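Swapping 4-chlorophenyl for cyclohexyl on a carbonyl carbon

The compounds below may be only part of what the source reports. "The series", "measured", "known", "first", "only" and "open" are said of these compounds alone.

Compound 1 `O=C(Nc1nnc(-c2cccc(O)c2O)s1)c1ccc(Cl)cc1` gives 9600 nM
Compound 2 `CC(=O)Nc1nnc(-c2ccc(O)c(O)c2)s1` gives 42500 nM

Both numbers come from a functional assay on HL-60 cells (Homo sapiens) for cytotoxicity, read by MTT assay, with a stated time of 72 h (on this read-out higher numbers stand for weaker inhibition and lower numbers for stronger inhibition), and compound 1 holds the lower of the two, with a gap to compound 2 that lies beyond the usual scatter of repeated measurements. Compound 3 `O=C(Nc1nnc(-c2cccc(O)c2O)s1)C1CCCCC1` keeps the core of compound 1 but carries cyclohexyl in place of 4-chlorophenyl on a carbonyl carbon. Among the measured compounds shown here, the two measured compounds differ in more than one place, so no measured pair shows this swap directly, and any expectation is uncertain. A modest move toward a higher number, meaning weaker inhibition, is expected, near the edge of the scatter. The estimated step is a 1.9-fold higher number from compound 1 to compound 3 (0.27 log units; within the scatter) in this assay and it could prove smaller or larger. The expected value for compound 3 is 18000 nM (estimated range 6000 nM to 50000 nM).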

Compound 3, half-maximal inhibitory concentration: 7900 nM
Compound 3: middle estimate off by 2.3-fold (0.36 log units), on the high side; the measured number falls inside the stated range.
By their numbers in this assay, from the lowest: compounds 3 and 1 (each within the scatter of the next); then compound 2.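

In this assay putting cyclohexyl in place of 4-chlorophenyl on a carbonyl carbon gives a 1.2-fold lower number from compound 1 to compound 3 (0.08 log units; within the scatter) and so leaves the two compounds indistinguishable on this read-out. Among the compounds shown here, this is the first direct look at this position, as compound 1 and compound 2 differ in more than one place. It shows that here the aromatic ring with its chlorine can be exchanged for a non-aromatic ring of carbon only with no measurable difference in cytotoxicity, though nothing shown explains why the two groups read alike. On these data alone, whether this position needs a ring at all remains open, since compound 1 and compound 3 both carry a six-membered one. A longer chain, an amine or a carboxylic acid in that place, on the same core, would show how far this tolerance extends.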